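The source may report more compounds than this note shows. Statements on the series, on what has been measured and on what is new or still open speak of the compounds shown alone.

For the measured compounds named here, only two compounds sharing one core have been tested so far in a functional assay on OVCAR-3 cells (Homo sapiens) for antiproliferative activity, read by MTT assay, with a stated time of 24 h; on this read-out higher numbers stand for weaker inhibition and lower numbers for stronger inhibition. Compound 1 `Cc1ccccc1C(=O)NNC(=O)c1ccccc1NS(=O)(=O)c1cnc(O)nc1O` gives > 20000 nM, which is a limit of the assay and not a number. Going by the values given here, compound 2 `O=C(NNC(=O)c1ccccc1NS(=O)(=O)c1cnc(O)nc1O)c1ccccc1Cl` gives 18200 nM, the only true number so far, so there is no measured series to rank it within. The picture is framed by the limit of > 20000 nM in this assay, at which 1 of the 2 values shown sits.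

Compound 3 `O=C(NNC(=O)c1ccccc1NS(=O)(=O)c1cnc(O)nc1O)c1ccccc1F` differs from compound 2 in one place: fluoro in place of chloro on an aromatic carbon. Here, fluoro takes the place of chloro on an aromatic carbon, ortho to a large group. Among the compounds with values here, one measured step bears on this, another swap on an aromatic carbon, with chloro in place of methyl: an at least 1.0-fold lower number from compound 1 to compound 2 (0.04 log units; that floor lies within the scatter). That step is only a floor and lies within the scatter, so it shows no clear effect of changing this group. No step beyond the scatter is therefore expected in this assay, and no direction can be favoured. The estimated change is a 1.0-fold higher number from compound 2 to compound 3 (0.02 log units; within the scatter). Compound 3 is expected to give 19000 nM, with an estimated range from 10000 nM to 38000 nM.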

Compound 3, half-maximal inhibitory concentration: 15300 nM
Compound 3: the middle estimate sits 1.2-fold (0.09 log units) above what was measured, within the range that was stated.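

For the compounds shown here, at this position, on an aromatic carbon ortho to a large group, the swap of fluoro for chloro gives the first step between two true numbers in this assay: a 1.2-fold lower number from compound 2 to compound 3 (0.08 log units; within the scatter). Compound 1 has a limit and not a number, so the swap of methyl for fluoro can be read only as a floor: an at least 1.3-fold lower number from compound 1 to compound 3 (0.11 log units; that floor lies within the scatter). Taken together, exchanging chloro, fluoro and methyl at this position gives no step that can be read as beyond the scatter, and the series remains framed by a limit: the limit of > 20000 nM in this assay, at which 1 of the 3 values shown sits.

Still open, from the compounds shown here alone, is whether a different kind of group at this position, such as a methoxy group, an amine or a carboxylic acid, would move the number beyond the scatter. Also open, going by these compounds, is whether placing the fluoro on another carbon of the same ring, or changing the shared core instead, would matter more, and these three compounds give no reason for the differences among them.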